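A few compounds are considered here, and "the series" means these few. Any claim that something is new, unique, unknown or untested is made for them only; others in the source may bear on it.

In a functional assay on HUVEC cells (Homo sapiens) for inhibition, with a stated time of 4 days (a lower number here means a stronger inhibitor, a higher number a weaker inhibitor), compound 1 `COc1ccc(C(N)=O)cc1/C=C/c1ccccc1` gives 2400 nM and compound 2 `COc1ccc(C(N)=O)cc1/C=C/c1ccccc1F` gives 2000 nM. Among the measured compounds shown here, these are the only two measurements so far, and they lie within the scatter of each other, so compound 2 cannot be ranked above or below compound 1. Compound 3 `COc1ccc(C(N)=O)cc1/C=C/c1ccccc1C` keeps the core of compound 2 and makes a single change: methyl in place of fluoro on an aromatic carbon. This puts methyl in place of fluoro on an aromatic carbon, ortho to a large group. For the measured compounds named here, one measured step bears on this change, fluoro in place of hydrogen on that carbon, and a 1.2-fold lower number from compound 1 to compound 2 (0.08 log units; within the scatter) is small. Going by the values given here, no compound with methyl there has been measured, so this evidence is thin and the range must stay wide. The expected step is a 1.1-fold higher number from compound 2 to compound 3 (0.04 log units; within the scatter), which means no change beyond the scatter is expected. For compound 3 the estimated value is 2200 nM, with an expected range from 900 nM to 5500 nM.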

Compound 3, half-maximal inhibitory concentration: 2300 nM
Estimate against measurement, compound 3: 1.0-fold (0.02 log units) below, within the range that was stated.
By their numbers in this assay, from the lowest: compounds 2, 3 and 1 (each within the scatter of the next).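

In this assay this aromatic carbon, ortho to a large group, now carries hydrogen, fluoro or methyl: methyl in place of fluoro gives a 1.2-fold higher number from compound 2 to compound 3 (0.06 log units; within the scatter) and methyl in place of hydrogen gives a 1.0-fold lower number from compound 1 to compound 3 (0.02 log units; within the scatter) as the second step at the same place. Both steps lie within the scatter, so these three groups cannot be told apart here, and a carbon group on this position shows no change beyond what fluoro showed. Nothing measured here offers an explanation for this result.

Still open, as far as these compounds go, is whether an amine, a carboxylic acid or a longer chain on this carbon would move the number beyond the scatter. Also open, from the compounds shown here alone, is whether fluoro or methyl on other carbons of this ring would behave the same way.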